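Ring exchange on the diaryl chain carbon of the series

A few compounds are considered here, and "the series" means these few. Any claim that something is new, unique, unknown or untested is made for them only; others in the source may bear on it.

Compound 1 `N=C(NCCCc1c[nH]cn1)NCCC(c1ccccc1)c1ccccn1` and compound 2 `N=C(NCCCc1c[nH]cn1)NCCC(c1ccccn1)c1ccccc1F` share the same core and differ only on one aromatic ring. In a functional assay on cardiac atrium for agonist activity at histamine H2 receptor (Cavia porcellus) (on this read-out higher numbers stand for higher potency (the scale is a negative logarithm) and lower numbers for lower potency), compound 1 gives 7.39, and in this assay compound 2 gives 7.46. Among the compounds with values here, of the two numbers so far, compound 2 carries the numerically larger one, but the gap to compound 1 is within the scatter, so the two cannot be told apart.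

Compound 3 `N=C(NCCCc1c[nH]cn1)NCCC(c1ccccn1)c1ccccn1` differs from compound 2 by pyridin-2-yl in place of 2-fluorophenyl on a saturated chain carbon bound to an aromatic carbon and a saturated chain carbon. Within the data shown here, no measured step covers an exchange of this kind. Among the measured compounds shown here, the only step available, a number 0.07 log units higher from compound 1 to compound 2 (within the scatter), touches the same aromatic ring at the same place and shows that a change there left this assay unmoved within the scatter. Since nothing in the two measured compounds distinguishes one six-membered aromatic ring from another at this place, compound 3 is expected to show a step of a number 0.06 log units lower from compound 2 to compound 3 (within the scatter) in this assay, none beyond the scatter. The estimate for compound 3 in this assay is 7.4, with a range from 6.9 to 7.9.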

Compound 3, negative logarithm of the half-maximal effective concentration: 6.9
For compound 3 the middle estimate is 0.50 log units above the measured one; the range from low to high includes it.
By their numbers in this assay, from the lowest: compound 3; then compounds 1 and 2 (each within the scatter of the next).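

In this assay the ring on the saturated chain carbon bound to an aromatic carbon and a saturated chain carbon does matter, which the fluoro exchange alone could not show: pyridin-2-yl in place of 2-fluorophenyl gives a number 0.56 log units lower from compound 2 to compound 3 (beyond the scatter) and pyridin-2-yl in place of phenyl gives a number 0.49 log units lower from compound 1 to compound 3 (beyond the scatter) as its matching step. Both steps are modest but beyond the scatter, and they start from two compounds that cannot be told apart, so a second pyridin-2-yl at this place lowers the number whichever of the two carbon-only rings it replaces. No measurement at hand bears on why the number falls.

Open, on these data alone, is whether an aromatic ring of carbon only is what this place favours, or whether other rings would hold the number as well; a thiophen-2-yl ring or a cyclohexyl group in place of pyridin-2-yl would separate these cases. Also open, as far as these compounds go, is whether a chloro or a methoxy group in place of the fluoro of compound 2 would stay within the scatter as the fluoro did.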